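The compounds below may be only part of what the source reports. "The series", "measured", "known", "first", "only" and "open" are said of these compounds alone.

Measured in a functional assay on HepG2 cells (Homo sapiens) for antiproliferative activity, read by MTT assay, with a stated time of 72 h; on this read-out higher numbers stand for weaker inhibition and lower numbers for stronger inhibition:
- compound 1 `O=C(N/N=C/c1ccc(F)cc1)Nc1ccc(Oc2ccnc3[nH]ccc23)c(F)c1`: 3880 nM
- compound 2 `O=C(N/N=C/c1cccc([N+](=O)[O-])c1)Nc1ccc(Oc2ccnc3[nH]ccc23)c(F)c1`: 5180 nM
- compound 3 `O=C(N/N=C/c1ccc(F)cc1)Nc1ccc(Oc2ccnc3[nH]ccc23)cc1`: 3430 nM

Compound 3 gives 3430 nM, a number within the scatter of both other values, so none of the three compounds stands apart from the rest. The unmeasured compound 4 `CN(C)CCn1cccc1/C=N/NC(=O)Nc1ccc(Oc2ccnc3[nH]ccc23)cc1` keeps the core of compound 3 and differs only in the group on a carbon with a double bond to nitrogen: 1-(2-(dimethylamino)ethyl)-1H-pyrrol-2-yl in place of 4-fluorophenyl on a carbon with a double bond to nitrogen.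

Among the measured compounds shown here, two measured steps bear on this. The closer one puts 3-nitrophenyl in place of 4-fluorophenyl at that same place and gives a 1.3-fold higher number from compound 1 to compound 2 (0.13 log units; within the scatter). The other puts hydrogen in place of fluoro on an aromatic carbon and gives a 1.1-fold lower number from compound 1 to compound 3 (0.05 log units; within the scatter). This second change lies elsewhere in the molecule, so it says less about compound 4.

Neither step moved the number in this assay beyond the scatter. However, no measured compound carries a five-membered aromatic ring or a dimethylamino group at this place, so both are only a weak guide. No change beyond the scatter is therefore expected, though a real move in either direction remains possible. The expected step is a 1.1-fold lower number from compound 3 to compound 4 (0.06 log units; within the scatter).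

For compound 4 the estimated value is 3000 nM, with an expected range from 800 nM to 10000 nM.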

Compound 4, half-maximal inhibitory concentration: "not active" (no number reported)
Nothing numeric was reported for compound 4; no gap can be computed for the estimate.
By their numbers in this assay, from the lowest: compounds 3, 1 and 2 (each within the scatter of the next).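

In this assay, among the compounds shown here, compound 4 is reported only as "not active", with no number, so no step from compound 3 to compound 4 can be read. The compounds shown leave open how far compound 4 lies from compound 3 on this read-out. Nothing measured here offers an explanation for the result.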